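This account rests on a few compounds, and the source may have more. Where it says the series, first, only, none or still open, it means among the compounds named here.

Measured so far:
compound 1 `O=C(/C=C1\CCc2ccc(F)cc21)NCCO` — 42%
compound 2 `O=C(/C=C1\CCc2c(F)cc(F)cc21)NC1CC1` — 38%

In a functional assay on the whole organism with Rattus norvegicus as the target, at a dose of 20 mg/kg by the oral route (on this read-out lower numbers stand for less inhibition and higher numbers for more inhibition at the one dose given (going by the name of the read-out)), compound 1 gives 42%, the higher of the two numbers at hand. Its nearest neighbour is compound 2, which in this assay gives 38%, a figure within the scatter of compound 1, so the two cannot be told apart on this read-out.

The step under study leads from compound 1 to compound 3 `O=C(/C=C1\CCc2ccc(F)cc21)N1CCC1`, which has not yet been measured in this assay. The difference between the two structures is azetidin-1-yl in place of (2-hydroxyethyl)amino on a carbonyl carbon. Among the compounds with values here, no measured pair in this set shows a change of this kind, so nothing here tells how large a step to expect or in which direction. With only the number of compound 1 as anchor, the expectation for compound 3 in this assay is a value close to that of compound 1, with a step of a number 6 percentage points lower from compound 1 to compound 3 (within the scatter) that need not exceed the scatter. Compound 3 is accordingly estimated at 36%, in a range from 15% to 56%.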

Compound 3, a percentage reported as inhibition, in the whole organism at one dose (the size of the read-out at that dose, not a potency): 14%
Beside the measured number, compound 3's estimate is 22 percentage points above it, outside the stated range (below it).
By their numbers in this assay, from the lowest: compound 3; then compounds 2 and 1 (each within the scatter of the next).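

Swapping (2-hydroxyethyl)amino for azetidin-1-yl on the carbonyl carbon, with the rest of compound 1 unchanged, gives in this assay a step of a number 28 percentage points lower from compound 1 to compound 3 (beyond the scatter), so the group at this place can move the read-out by more than the scatter. The two groups have the same heavy-atom count, so this step does not go with a change in that count; they differ instead in the ring, which only azetidin-1-yl has, and in the hydrogen-bond donors and acceptors, which only (2-hydroxyethyl)amino has. No measurement at hand bears on why the read-out falls.

Which of these differences matters remains open: an open-chain ethylamino or dimethylamino group on the same carbonyl carbon could help separate them. Going by these compounds, whether a larger ring, such as pyrrolidin-1-yl or morpholin-4-yl, would behave like azetidin-1-yl also remains open.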